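The source may report more compounds than this note shows. Statements on the series, on what has been measured and on what is new or still open speak of the compounds shown alone.

Compound 3, `COc1c(F)cccc1C1CCN(c2ccn3c(CC4CC4)nnc3c2Cl)CC1`, stands at the edge of what an ADME assay on a cell-free system (plasma, Rattus norvegicus) for protein binding (on this read-out lower numbers stand for a smaller free fraction and higher numbers for a larger free fraction), can report. In this assay compound 3 gives < 0.01, which is a limit of the assay rather than a number. Compound 1, `COc1ccccc1C1CCN(c2ccn3c(CC4CC4)nnc3c2Cl)CC1`, gives < 0.01, likewise a limit. Compound 2, `COc1ccc(F)cc1C1CCN(c2ccn3c(CC4CC4)nnc3c2Cl)CC1`, gives < 0.01, again a limit. All three values sit at the limit of < 0.01 in this assay, at which 3 of the 3 values shown sit, so the steps a step that the two limits leave unreadable from compound 1 to compound 2, a step that the two limits leave unreadable from compound 1 to compound 3 and a step that the two limits leave unreadable from compound 2 to compound 3 cannot be read in size or direction. Compound 4, `COc1c(F)ccc(F)c1C1CCN(c2ccn3c(CC4CC4)nnc3c2Cl)CC1`, differs from compound 3 by fluoro in place of hydrogen on an aromatic carbon. Since every earlier fluoro addition left the value at the limit, compound 4 is expected to give 0.005, between 0.002 and 0.01. The expected step is a step that the limit leaves unreadable from compound 3 to compound 4, none beyond the scatter.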

Compound 4, unbound fraction: < 0.01
Compound 4: a limit, no number (the forecaster's own chance of this, stated with the estimate: 85%); the middle value does not contradict the limit.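

Compound 4 gives only a limit, as do compounds 1, 2 and 3, and no step among these four compounds can be read in size or direction. The compounds shown leave open how large each unbound fraction really is, and whether any fluoro substitution changes it.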